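A few compounds are considered here, and "the series" means these few. Any claim that something is new, unique, unknown or untested is made for them only; others in the source may bear on it.

Measured in a physicochemical assay for lipophilicity, at pH 7.4; on this read-out higher numbers stand for higher lipophilicity and lower numbers for lower lipophilicity:

compound 1 `COC(c1cc(Cl)c2c(c1Cl)C(=O)N(Cc1c(C)cc(C)[nH]c1=O)CC2)C1CCOCC1`: 3.4; 3.5 (2 entries)
compound 2 `Cc1cc(C)c(CN2CCc3c(Cl)cc([C@H](CO)[C@H]4CCCO4)c(Cl)c3C2=O)c(=O)[nH]1`: 2.1
compound 3 `COC(c1cc(Cl)c2c(c1Cl)C(=O)N(Cc1c(C)cc(C)[nH]c1=O)CC2)C1CCS(=O)(=O)CC1`: 2.2; 2.2 (2 entries)

Compound 2 reads 2.1 in this assay and so lies within the usual scatter of compound 3 at 2.2; 2.2 (2 entries) and clearly under compound 1 at 3.4; 3.5 (2 entries) on the same scale. Compound 2 rests on one reading only, whereas the repeat entries of compound 1 [ the several entries of compound 1 in this assay, 3.4; 3.5 (2 entries) ] show how closely two measurements of one substance can agree.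

The next compound to be measured is compound 4 `Cc1cc(C)c(CN2CCc3c(Cl)cc([C@@H](CO)[C@@H]4CCOC4)c(Cl)c3C2=O)c(=O)[nH]1`, which keeps the shared core and changes one group on an aromatic carbon. The change is a group of 8 heavy atoms (6 carbon, 2 oxygen; one five-membered non-aromatic ring with 1 hetero atom) in place of a group of 8 heavy atoms (6 carbon, 2 oxygen; one five-membered non-aromatic ring with 1 hetero atom), on an aromatic carbon and it is a subtle one: the two compounds have the same atoms, joined differently.

For the measured compounds named here, no measured pair differs in one place only, so the data offer no direct guide to the size of this step. With the counts of the old and new groups matching, no step beyond the scatter is expected in this assay and no clear direction can be called. The estimated a number 0.10 log units lower from compound 2 to compound 4 (within the scatter) is therefore small. For compound 4 the expected value is 2 with an estimated range from 1.7 to 2.4 in this measurement.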

Compound 4, distribution coefficient: 2
Compound 4: middle estimate and measured number agree at the digits printed, and the stated range covers the measured number.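

For the compounds shown here, this is the first pair in the set that differs in one place only, so it gives a direct look at the group on this aromatic carbon, ortho to a chloro group. In this assay the rearranged group gives a number 0.10 log units lower from compound 2 to compound 4 (within the scatter), so joining the same atoms differently, with the ring still five-membered and still holding one hetero atom, does not separate the two compounds on this read-out. A gap like this is of the size seen between repeat readings of a single substance: the several entries of compound 1 in this assay, 3.4; 3.5 (2 entries)

One pair of groups built from the same atoms cannot show how strongly this position responds when the atoms themselves change: an amine, a carboxylic acid or a longer chain on the same aromatic carbon could shift the number by an amount these compounds do not indicate. As far as these compounds go, it also stays open whether the same rearrangement would give so small a step in this assay on a core carrying other groups, or in a different kind of measurement altogether.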